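Working notes on the step from compound 2 to compound 3

The source may report more compounds than this note shows. Statements on the series, on what has been measured and on what is new or still open speak of the compounds shown alone.

Compound 2 `O=S(=O)(Nc1ccccc1NS(=O)(=O)c1ccc(Cl)cc1)c1ccc(F)cc1` gives 27300 nM in an assay for binding affinity to protein lin-28 homolog A (Mus musculus), with a stated time of 1 h; a lower number here means a stronger inhibitor, a higher number a weaker inhibitor. Compound 1 `O=S(=O)(Nc1ccccc1NS(=O)(=O)c1ccccc1)c1ccccc1` gives 32200 nM in this assay; the two numbers differ by less than the scatter, so neither compound stands apart from the other. Compound 3 `O=S(=O)(Nc1ccccc1NS(=O)(=O)c1cccc(Br)c1)c1ccc(F)cc1` differs from compound 2 by 3-bromophenyl in place of 4-chlorophenyl on a sulfonyl sulfur. Within the data shown here, no step between measured compounds bears on this kind of change, so there is no measured precedent to lean on. The expected step in this assay is a 1.0-fold higher number from compound 2 to compound 3 (0.01 log units; within the scatter), nothing beyond the scatter in either direction. Compound 3 is therefore estimated at 28000 nM, with a range from 12000 nM to 65000 nM.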

Compound 3, half-maximal inhibitory concentration: 16200 nM
Beside the measured number, compound 3's estimate is 1.7-fold (0.24 log units) above it; low and high end bracket the measured number.
By their numbers in this assay, from the lowest: compounds 3, 2 and 1 (each within the scatter of the next).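

In this assay, 3-bromophenyl in place of 4-chlorophenyl on a sulfonyl sulfur gives a 1.7-fold lower number from compound 2 to compound 3 (0.23 log units; within the scatter) and so is tolerated at this position without a step that stands clear of the scatter. The change swaps the halogen and moves it on the ring at once, so neither part can be read alone. No measured evidence bears on this result.

Still open, going by these compounds, is whether 3-chlorophenyl would separate the halogen from its place on the ring. Also open, on these data alone, is whether an amine or a carboxylic acid on this ring would take the number beyond the scatter.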